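Methyl for Trifluoromethyl: an Untested Step from a Limit

The source may hold more compounds than are shown below. What is called first, only, known or untested is meant among the compounds shown, and "the series" means these compounds.

Compound 1 `COc1ccc2sc(NC(=O)c3ccc(C(F)(F)F)cc3)nc2c1` is one of three close relatives measured in a functional assay on SK-HEP1 cells (Homo sapiens) for antiproliferative activity, read by sulforhodamine B assay; on this read-out lower numbers stand for stronger inhibition of growth and higher numbers for weaker inhibition of growth. Compound 1 gives > 10 ug/mL, which is a limit of the assay rather than a number. Compound 3 `COc1cccc2sc(NC(=O)c3ccc(C#N)cc3)nc12` also gives > 10 ug/mL, again a limit. Compound 2 `COc1ccc(C(=O)Nc2nc3c(OC)cccc3s2)cc1` gives 2.11 ug/mL. Two of the three results sit at the limit of > 10 ug/mL in this assay, at which 2 of the 3 values shown sit, so compound 1 is not placed against the others by a number. Among the measured compounds shown here, the one measured step, an at least 4.7-fold higher number from compound 2 to compound 3 (0.67 log units; beyond the scatter), concerns a different change, cyano in place of methoxy, and shows only that a single swap of a group on the same kind of ring can move a compound from a number to a limit. From the compounds shown here alone, compound 4 `COc1ccc2sc(NC(=O)c3ccc(C)cc3)nc2c1` is untested; from compound 1 it changes by methyl in place of trifluoromethyl on an aromatic carbon. For the measured compounds named here, no measured step matches this change, so no clear direction is expected in this assay. The estimate for compound 4 is 8 ug/mL, between 3 ug/mL and 25 ug/mL, a step of an at least 1.2-fold lower number from compound 1 to compound 4 (0.09 log units; that floor lies within the scatter) expected to leave it near the limit.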

Compound 4, concentration for 50% growth inhibition: > 10 ug/mL
Compound 4 was reported as a limit (the forecaster's own chance of this, stated with the estimate: 55%); at least 1.2-fold (0.09 log units) between middle value and limit.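

Compound 1 and compound 4 are both reported only as limits, not as numbers, so no step between them can be read: the limit of > 10 ug/mL in this assay, at which 3 of the 4 values shown sit.

The compounds shown leave open whether trifluoromethyl or methyl gives stronger inhibition of growth in this assay.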